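A Methyl Added to the Five-Membered Ring of Compound 2

The source may report more compounds than this note shows. Statements on the series, on what has been measured and on what is new or still open speak of the compounds shown alone.

Measured compounds:
Compound 1, `c1ccc(-c2cnccn2)c(OCC2=NCCN2)c1`, 2.51 nM
Compound 2, `c1ccc(-c2ccns2)c(OCC2=NCCN2)c1`, 5.01 nM

Both compounds were tested in a functional assay for activation of Alpha-1A adrenergic receptor (Homo sapiens), read by calcium flux; a lower number here means that less compound is needed, a higher number that more compound is needed for the effect. Compound 1 gives 2.51 nM, and compound 2 gives 5.01 nM. These two numbers stand close together: the one measured step, a 2.0-fold higher number from compound 1 to compound 2 (0.30 log units; within the scatter), lies within the scatter, so compound 2 cannot be set apart from compound 1 on the numbers shown.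

Compound 3, `Cc1cc(-c2ccccc2OCC2=NCCN2)sn1`, has not yet been measured. It differs from compound 2 by methyl in place of hydrogen on an aromatic carbon. For the measured compounds named here, no measured step in this small set concerns a methyl; the single known step is the exchange of one five-membered or six-membered aromatic ring for another, and that step stayed within the scatter. There is therefore no measured ground for expecting a step beyond the scatter in this assay for this small addition, in either direction.

On that basis compound 3 is expected to give about 5 nM, with a range from 1.5 nM to 16 nM. The step this estimate means, a 1.0-fold lower number from compound 2 to compound 3 (0.00 log units; within the scatter), is expected to stay within the scatter.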

Compound 3, half-maximal effective concentration: 158 nM
Compound 3: middle estimate off by 32-fold (1.50 log units), on the low side; the measured number lies above the stated range.
By their numbers in this assay, from the lowest: compounds 1 and 2 (each within the scatter of the next); then compound 3.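

In this assay, for the compounds shown here, the earlier pair showed only that one aromatic ring could stand in for another with a step inside the scatter. This result shows that the aromatic carbon next to the ring nitrogen, two ring bonds from the ring sulfur, is sensitive to substitution: a single methyl in place of hydrogen there gives a 32-fold higher number from compound 2 to compound 3 (1.50 log units; beyond the scatter), a large step from the smallest change in the set. Set against the pyrazin-2-yl group, the 3-methyl-1,2-thiazol-5-yl group gives a 63-fold higher number from compound 1 to compound 3 (1.80 log units; beyond the scatter), so one added carbon counts for far more here than the exchange of the rings did, and nothing measured here accounts for the loss.

Going by these compounds, what stays open is whether the step belongs to methyl itself or to any group on this carbon, since a fluorine, a methoxy or an ethyl at the same place would tell these apart. On these data alone, it also stays open whether a methyl elsewhere on the five-membered ring, or on the pyrazin-2-yl ring of compound 1, would bring a step of similar size.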